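The source may report more compounds than this note shows. Statements on the series, on what has been measured and on what is new or still open speak of the compounds shown alone.

Values so far, measured in a functional assay on HUVEC cells (Homo sapiens) for inhibition, with a stated time of 4 days; on this read-out lower numbers stand for stronger inhibition and higher numbers for weaker inhibition

- compound 1 `COc1ccc(C(C)=O)cc1COc1ccc(Cl)cc1` gives 1200 nM
- compound 2 `COc1ccc(C(N)=O)cc1COc1ccc(Cl)c(C)c1` gives 640 nM

For the measured compounds named here, compound 2 at 640 nM has the lower of only two numbers, but it lies within the usual scatter of compound 1 at 1200 nM and so cannot be ranked against it.

The next step leads to compound 3 `COc1ccc(C(N)=O)cc1COc1ccc(Cl)cc1` and the change is hydrogen in place of methyl on an aromatic carbon which in words is hydrogen in place of methyl on an aromatic carbon. Going by the values given here, no pair of measured compounds differs in one place only, so the data give no direct size for this change. Compound 1 also lacks this methyl and gives 1200 nM but it differs from compound 3 in another place too, so it is only a loose guide. In this assay a small move towards a higher number is expected, possibly none beyond the scatter. The estimated step is a 1.4-fold higher number from compound 2 to compound 3 (0.15 log units; within the scatter) and it remains an expectation. For compound 3 the estimated value is 900 nM with an expected range of 350 nM to 2300 nM in this read-out.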

Compound 3, half-maximal inhibitory concentration: 660 nM
For compound 3 the middle estimate is 1.4-fold (0.13 log units) above the measured one; low and high end bracket the measured number.
By their numbers in this assay, from the lowest: compounds 2, 3 and 1 (each within the scatter of the next).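

In this assay, for the compounds shown here, hydrogen in place of methyl on the aromatic carbon ortho to a chloro group gives a 1.0-fold higher number from compound 2 to compound 3 (0.01 log units; within the scatter), so the methyl at this position is the first single-place change to be read directly, and the read-out does not separate the two compounds. Amino in place of methyl on a carbonyl carbon gives a 1.8-fold lower number from compound 1 to compound 3 (0.26 log units; within the scatter), so this second single-place comparison also stays inside the scatter, and compound 3 links two compounds that differ from each other in two places. No supporting measurement bears on the reason for either result.

The compounds shown leave open whether this aromatic carbon tolerates anything other than hydrogen or methyl, for instance an ethyl, a methoxy group or a trifluoromethyl group, since a single small group says little about larger ones. They also leave open what a carboxylic acid, a methylamino group or a longer chain at the carbonyl carbon would give, and whether any such group would produce a step beyond the scatter.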